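The source may report more compounds than this note shows. Statements on the series, on what has been measured and on what is new or still open speak of the compounds shown alone.

Measured so far in an assay on membranes from CHO cells for displacement of a labelled ligand from adenosine receptor A1 (Homo sapiens), read by scintillation counting, with a stated time of 60 min, tested at 1 uM; on this read-out lower numbers stand for less inhibition and higher numbers for more inhibition at the one concentration tested (going by the name of the read-out):
compound 1, `CCN(CC)C(=O)C1=C(C)NC(=O)NC1c1ccsc1`: 11%
compound 2, `CC1=C(C(=O)OC2CCC2)C(c2ccsc2)NC(=O)N1`: 40%

Compound 2 stands highest of the two numbers. For the measured compounds named here, its only neighbour is compound 1, and the step of a number 29 percentage points higher from compound 1 to compound 2 (beyond the scatter) is the one measured step so far; it is a change at the carbonyl carbon, cyclobutyloxy in place of diethylamino, and is beyond the scatter.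

Compound 3, `CC1=C(C(=O)OC2CCCC2)C(c2ccsc2)NC(=O)N1`, is not yet measured. It differs from compound 2 in cyclopentyl in place of cyclobutyl on an oxygen next to a carbonyl group. Going by the values given here, no measured step bears directly on this change: the one step known concerns the group on the carbonyl carbon as a whole, not the size of the ring on the ester oxygen. With the ester already in place in compound 2, a one-carbon enlargement of that ring gives no reason from the data to expect a step beyond the scatter in this assay in either direction. The expected step is therefore small, a number 5 percentage points higher from compound 2 to compound 3 (within the scatter).

Compound 3 is estimated at 45% in this assay, with a range from 25% to 65%.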

Compound 3, a percentage reported as inhibition, at one concentration (the size of the read-out at that concentration, not a potency): 5%
Compound 3: the middle estimate sits 40 percentage points above what was measured; measured number outside the range, below it.
By their numbers in this assay, from the lowest: compounds 3 and 1 (each within the scatter of the next); then compound 2.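

In this assay, the group on the ester oxygen turns out to be a sensitive point: cyclopentyl in place of cyclobutyl on an oxygen next to a carbonyl group gives a number 35 percentage points lower from compound 2 to compound 3 (beyond the scatter) and removes the whole gain seen earlier at the carbonyl carbon. The ester alone therefore does not account for the higher number of compound 2, since an ester carrying cyclopentyloxy where diethylamino stood on the carbonyl carbon gives a number 6 percentage points lower from compound 1 to compound 3 (within the scatter) and leaves the two compounds unseparated. Of the groups shown on this carbonyl carbon, only cyclobutyloxy stands apart, and nothing available explains why the four-membered and five-membered rings differ so sharply.

Going by these compounds, it remains open whether the higher number belongs to the cyclobutyl ring alone or also extends to cyclopropyl or to an open chain such as isobutyl on the same oxygen. Also open, on these data alone, is whether cyclobutylamino on the carbonyl carbon would keep that number, which would show how far it depends on the ester oxygen rather than on the ring.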